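This account rests on a few compounds, and the source may have more. Where it says the series, first, only, none or still open, it means among the compounds named here.

Values in a functional assay on MKN-74 cells (Homo sapiens) for antiproliferative activity, with a stated time of 24 h; on this read-out lower numbers stand for stronger inhibition and higher numbers for weaker inhibition:
Compound 1 `NC(=O)c1c(NC(=O)c2ccccc2Cl)sc2c1CCN(Cc1ccccc1F)C2`: 12900 nM
Compound 2 `NC(=O)c1c(NC(=O)c2ccccc2Cl)sc2c1CCN(Cc1c(Cl)cccc1Cl)C2`: 4740 nM
Compound 3 `NC(=O)c1c(NC(=O)c2cccc([N+](=O)[O-])c2)sc2c1CCN(Cc1c(Cl)cccc1Cl)C2`: 13500 nM

Compound 2 gives the lowest number of the three, with compound 1 nearest (a 2.7-fold lower number from compound 1 to compound 2 (0.43 log units; beyond the scatter)) and compound 3 furthest (a 2.8-fold higher number from compound 2 to compound 3 (0.45 log units; beyond the scatter)), both steps modest and beyond the scatter.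

Compound 4 `NC(=O)c1c(NC(=O)c2ccccc2Cl)sc2c1CCN(C(=S)Nc1ccccc1Br)C2` differs from compound 2 at the same position that was varied between compound 1 and compound 2: a group of 10 heavy atoms (7 carbon, 1 nitrogen, 1 sulfur, 1 bromine; one six-membered aromatic ring of carbon only) in place of a group of 9 heavy atoms (7 carbon, 2 chlorine; one six-membered aromatic ring of carbon only), on an amine nitrogen in a ring. For the measured compounds named here, the only step bearing on this position, the one from compound 1 to compound 2, is modest, but it exchanged one substituted benzyl for another, whereas here the group entering carries a double bond outside aromatic rings and a hydrogen-bond donor and acceptor. Going by the values given here, no measured step covers such an exchange, so the direction is open and the expected change is set near zero with a wide range: a 1.9-fold higher number from compound 2 to compound 4 (0.28 log units; within the scatter) is the estimated step, giving for compound 4 an expected value of 9000 nM (range 2500 nM to 32000 nM).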

Compound 4, half-maximal inhibitory concentration: 10800 nM
Compound 4: the middle estimate sits 1.2-fold (0.08 log units) below what was measured; the measured number falls inside the stated range.
By their numbers in this assay, from the lowest: compound 2; then compounds 4, 1 and 3 (each within the scatter of the next).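

On the amine nitrogen in a ring, the larger group with a double bond outside aromatic rings, a hydrogen-bond donor and a hydrogen-bond acceptor brings no gain in this assay: replacing 2,6-dichlorobenzyl gives a 2.3-fold higher number from compound 2 to compound 4 (0.36 log units; beyond the scatter). Set against the group in compound 1, the same entering group gives a 1.2-fold lower number from compound 1 to compound 4 (0.08 log units; within the scatter), so the two cannot be told apart. No supporting data bear on these steps. On these data alone, whether oxygen in place of the sulfur, or an unsubstituted benzyl or longer chain on this nitrogen, would shift the number remains open.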